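Meta-substituent swaps on an aryl imidazolylmethyl-piperazinone series

The source may hold more compounds than are shown below. What is called first, only, known or untested is meant among the compounds shown, and "the series" means these compounds.

Compound 1: `Cc1[nH]cnc1CN1CCN(c2cccc(Cl)c2)C1=O` — 12 nM
Compound 2: `Cc1[nH]cnc1CN1CCN(c2cccc(C#N)c2)C1=O` — 134 nM
Compound 3: `Cc1cccc(N2CCN(Cc3nc[nH]c3C)C2=O)c1` — 45.7 nM

In a functional assay (Cavia porcellus) for antagonist activity at Serotonin 3 (5-HT3) receptor (Homo sapiens) (on this read-out higher numbers stand for weaker inhibition and lower numbers for stronger inhibition), compound 3 stands second highest of the three numbers. Its nearest neighbour is compound 2, a step of a 2.9-fold lower number from compound 2 to compound 3 (0.47 log units; beyond the scatter); the furthest is compound 1, a step of a 3.8-fold higher number from compound 1 to compound 3 (0.58 log units; beyond the scatter). Compound 4, `Cc1[nH]cnc1CN1CCN(c2cccc([N+](=O)[O-])c2)C1=O`, differs from compound 3 by nitro in place of methyl on an aromatic carbon. Going by the values given here, the only measured steps at this position are an 11-fold higher number from compound 1 to compound 2 (1.05 log units; beyond the scatter) and a 3.8-fold higher number from compound 1 to compound 3 (0.58 log units; beyond the scatter), both raising the number when chloro is replaced. Because the step of an 11-fold higher number from compound 1 to compound 2 (1.05 log units; beyond the scatter) was large, a nitro group is expected to move in the same direction as cyano, giving an expected step of a 2.6-fold higher number from compound 3 to compound 4 (0.42 log units; beyond the scatter). Compound 4 is therefore estimated at 120 nM in this assay, with a range from 35 nM to 400 nM.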

Compound 4, antagonist equilibrium constant: 125 nM
Beside the measured number, compound 4's estimate is 1.0-fold (0.02 log units) below it; low and high end bracket the measured number.
By their numbers in this assay, from the lowest: compound 1; then compound 3; then compounds 4 and 2 (each within the scatter of the next).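

In this assay, nitro on this aromatic carbon cannot be told apart from cyano, with a 1.1-fold lower number from compound 2 to compound 4 (0.03 log units; within the scatter). It does separate from the other two groups, with a 2.7-fold higher number from compound 3 to compound 4 (0.44 log units; beyond the scatter) and a 10-fold higher number from compound 1 to compound 4 (1.02 log units; beyond the scatter), so among these four groups chloro gives the lowest number and methyl the next, while nitro and cyano share the high end. Nothing measured on hand accounts for this order.

The compounds shown leave open where an amine, a carboxylic acid or a methoxy group would fall at this position. They also leave open whether bromo or fluoro would stay close to chloro.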